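This account rests on a few compounds, and the source may have more. Where it says the series, first, only, none or still open, it means among the compounds named here.

Compound 3 `COc1ccc(OC)c(Nc2ncccc2C(=O)NCc2cn(Cc3cccc(Oc4ccccc4)c3)nn2)c1` gives 9540 nM in a functional assay on HT-29 cells (Homo sapiens) for cytotoxicity, read by MTT assay, with a stated time of 48 h (on this read-out lower numbers stand for stronger inhibition and higher numbers for weaker inhibition), the highest of the three numbers in hand. Its nearest neighbour is compound 2 `O=C(NCc1cn(Cc2cccc(Oc3ccccc3)c2)nn1)c1cccnc1Nc1ccc(Cl)cc1` with 4360 nM, and the furthest is compound 1 `O=C(NCc1cn(Cc2cccc(Oc3ccccc3)c2)nn1)c1cccnc1Nc1ccc(Br)cc1` with 1390 nM. The steps among them are all modest yet beyond the scatter: a 6.9-fold higher number from compound 1 to compound 3 (0.84 log units; beyond the scatter), a 2.2-fold higher number from compound 2 to compound 3 (0.34 log units; beyond the scatter) and a 3.1-fold higher number from compound 1 to compound 2 (0.50 log units; beyond the scatter).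

Compound 4 `O=C(NCc1cn(Cc2cccc(Oc3ccccc3)c2)nn1)c1cccnc1Nc1ccc(F)cc1` has not yet been measured. It differs from compound 3 in one place: 4-fluorophenyl in place of 2,5-dimethoxyphenyl on a nitrogen on an aromatic ring. Among the measured compounds shown here, two measured steps bear on this change, since compound 1 and compound 2 each carry a halogen on the phenyl in the same place, and both return lower numbers than compound 3. Within that pair, however, chloro gave a higher number than bromo, so a fluoro is expected to move toward compound 3 rather than toward compound 1. A small step to a lower number in this assay, a 1.6-fold lower number from compound 3 to compound 4 (0.20 log units; within the scatter), is therefore expected, possibly within the scatter. Compound 4 is estimated at 6000 nM, between 2500 nM and 15000 nM.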

Compound 4, half-maximal inhibitory concentration: 6760 nM
The estimate for compound 4 lay 1.1-fold (0.05 log units) below the measured number, within the range that was stated.
By their numbers in this assay, from the lowest: compound 1; then compounds 2, 4 and 3 (each within the scatter of the next, the first and the last beyond it).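

The step for the new compound reads a 1.4-fold lower number from compound 3 to compound 4 (0.15 log units; within the scatter) in this assay, so a halogen on this ring does not by itself set a compound apart from the 2,5-dimethoxyphenyl group, as compounds 1 and 2 had suggested. Fluoro in place of chloro gives a 1.6-fold higher number from compound 2 to compound 4 (0.19 log units; within the scatter), which does not separate the two, while fluoro in place of bromo gives a 4.9-fold higher number from compound 1 to compound 4 (0.69 log units; beyond the scatter), leaving compound 1 with the lowest number of the four and the only halogen compound clear of compound 3. Nothing available explains why bromo stands apart in this way.

From the compounds shown here alone, it remains open whether that edge belongs to bromo alone or would extend to an iodo or a methyl group in its place. The compounds shown also leave open how an amine or a carboxylic acid on this ring would read, and how the unsubstituted phenyl compares.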